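Switching the ring substituent on the core nitrogen for a branched chain

The source may hold more compounds than are shown below. What is called first, only, known or untested is meant among the compounds shown, and "the series" means these compounds.

Among the measured compounds shown here, compound 1 `Cc1cc(Nc2nn(Cc3cccnc3)c(=O)c3ccccc23)n[nH]1` is the single compound in this set with a numerical result. In a functional assay on MCF7 cells (Homo sapiens) for cytotoxicity (on this read-out lower numbers stand for stronger inhibition and higher numbers for weaker inhibition), compound 1 gives 13400 nM, a weak effect on this read-out. For the measured compounds named here, compound 2 `Cc1ccc(-n2nc(Nc3cc[nH]n3)c3ccccc3c2=O)cc1` belongs to the same series, but in this assay compound 2 has "not determined" (no result reported), so compound 1 stands alone and no comparison between measured compounds can be drawn.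

Compound 3 `Cc1cc(Nc2nn(CC(C)C)c(=O)c3ccccc23)n[nH]1` is the next compound to be tested. It differs from compound 1 in one place: isopropyl in place of pyridin-3-yl on a saturated chain carbon bound to an aromatic nitrogen. The group that leaves carries one hydrogen-bond acceptor and a ring; the group that enters is a short saturated chain without either.

Going by the values given here, no step between measured compounds is available, so the size of the change to be expected rests on the structural difference alone. The expectation is a step from compound 1 to compound 3 of a 1.2-fold higher number from compound 1 to compound 3 (0.08 log units; within the scatter), that is, no movement beyond the usual scatter, with a slight lean toward weaker inhibition. Compound 3 is therefore expected to give about 16000 nM in this assay, with an estimated range from 5000 nM to 50000 nM.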

Compound 3, half-maximal inhibitory concentration: 4200 nM
Compound 3: middle estimate off by 3.8-fold (0.58 log units), on the high side; measured number outside the range, below it.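

In this assay, isopropyl in place of pyridin-3-yl on a saturated chain carbon bound to an aromatic nitrogen gives a 3.2-fold lower number from compound 1 to compound 3 (0.50 log units; beyond the scatter) and so shows that the number in this series responds to a change at this position. The ring and the hydrogen-bond acceptor of pyridin-3-yl are not required for activity on this read-out, since the short saturated chain, which has neither, carries the lower number. No measurement at hand accounts for the shift, and it cannot be assigned to the loss of the ring, the loss of the acceptor or the drop in heavy atoms.

The ring and the acceptor leave together in this one step, so the compounds shown do not separate their contributions; phenyl in the place of pyridin-3-yl would keep the ring without the ring nitrogen, while a longer chain such as n-butyl or a cyclohexyl ring would test how far the saturated group can grow. On these data alone, whether the trend holds beyond this single pair also stays open, as this step is the only one that can be read.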